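Amide series: 2-fluorobenzyl to 4-methoxyphenyl

A few compounds are considered here, and "the series" means these few. Any claim that something is new, unique, unknown or untested is made for them only; others in the source may bear on it.

Compound 1 `COc1ccc2c(=O)c(/C=C/C(=O)NCc3ccccc3)coc2c1`: 11800 nM
Compound 2 `COc1ccc2c(=O)c(/C=C/C(=O)NCc3ccc(F)cc3)coc2c1`: > 100000 nM, a limit
Compound 3 `COc1ccc2c(=O)c(/C=C/C(=O)NCc3ccccc3F)coc2c1`: > 100000 nM, a limit

All values come from a functional assay on A549 cells (Homo sapiens) for inhibition, read by MTT assay, with a stated time of 48 h; on this read-out higher numbers stand for weaker inhibition and lower numbers for stronger inhibition. Compound 3 stands only at a limit, > 100000 nM, which is the limit of > 100000 nM in this assay, at which 2 of the 3 values shown sit. Compound 4 `COc1ccc(NC(=O)/C=C/c2coc3cc(OC)ccc3c2=O)cc1` has 4-methoxyphenyl in place of 2-fluorobenzyl on an amide-type nitrogen. The nearest measured steps are fluoro in place of hydrogen on an aromatic carbon: an at least 8.4-fold higher number from compound 1 to compound 2 (0.92 log units; beyond the scatter) and an at least 8.4-fold higher number from compound 1 to compound 3 (0.92 log units; beyond the scatter). The swap of fluorine positions gives a step that the two limits leave unreadable from compound 2 to compound 3. Neither readable step tests the new group, so the guidance is weak. Compound 4 has no fluoro, like compound 1 at 11800 nM, so a moderately lower number is expected. Another limit remains possible for compound 4. The estimated change is an at least 2.8-fold lower number from compound 3 to compound 4 (0.45 log units; beyond the scatter). For compound 4 the estimated value is 35000 nM, with an expected range of 7000 nM to 150000 nM.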

Compound 4, half-maximal inhibitory concentration: 23000 nM
Compound 4: the middle estimate sits 1.5-fold (0.18 log units) above what was measured; the range from low to high includes it.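

The 4-methoxyphenyl group on the amide-type nitrogen restores a measurable value, with an at least 4.3-fold lower number from compound 3 to compound 4 (0.63 log units; beyond the scatter) and an at least 4.3-fold lower number from compound 2 to compound 4 (0.63 log units; beyond the scatter). Against the unsubstituted benzyl of compound 1 there is a 1.9-fold higher number from compound 1 to compound 4 (0.29 log units; within the scatter), so compound 4 and compound 1 cannot be ordered. The loss of activity at this nitrogen is therefore confined so far to the two fluorobenzyl compounds, whose values remain limits: the limit of > 100000 nM in this assay, at which 2 of the 4 values shown sit.

Going by these compounds, how a 4-methoxybenzyl group would compare remains open, and it would separate the methoxy group from the change from benzyl to phenyl. Also open, on these data alone, is whether an amine or a carboxylic acid on the amide-type nitrogen would move the value beyond the scatter around compound 1.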